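The source may hold more compounds than are shown below. What is called first, only, known or untested is meant among the compounds shown, and "the series" means these compounds.

Three compounds share one core and differ only in the group attached to the amide carbonyl. Compound 1 `O=C(CN1CCCC1)N1CCC(NS(=O)(=O)c2cc(S(=O)(=O)c3ccccc3)ccc2C(F)(F)F)CC1` carries a pyrrolidin-1-yl on a saturated chain carbon bound to that carbonyl carbon; in an assay on isolated protein for binding affinity to secreted frizzled-related protein 1 (Homo sapiens), read by fluorescence (a lower number here means a stronger inhibitor, a higher number a weaker inhibitor), compound 1 gives 110 nM. In this assay compound 2 `O=C(Cn1ccnc1)N1CCC(NS(=O)(=O)c2cc(S(=O)(=O)c3ccccc3)ccc2C(F)(F)F)CC1` gives 30 nM, and compound 3 `CC(C)(C)C(=O)N1CCC[C@H]1C(=O)N1CCC(NS(=O)(=O)c2cc(S(=O)(=O)c3ccccc3)ccc2C(F)(F)F)CC1` gives 40 nM. Compound 3 stands well away from compound 1, as the step of a 2.8-fold lower number from compound 1 to compound 3 (0.44 log units; beyond the scatter) shows, and close to compound 2, since a 1.3-fold higher number from compound 2 to compound 3 (0.12 log units; within the scatter) lies within the scatter, so these two cannot be told apart on the numbers.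

Compound 4 `CN(C)c1ccc(C(=O)N2CCC[C@H]2C(=O)N2CCC(NS(=O)(=O)c3cc(S(=O)(=O)c4ccccc4)ccc3C(F)(F)F)CC2)cc1` keeps the whole of compound 3 apart from one change: 4-(dimethylamino)phenyl in place of tert-butyl on a carbonyl carbon. Among the measured compounds shown here, no measured step alters this tert-butyl, so nothing speaks directly to the change. What the measured steps do show is that alterations at the amide carbonyl have moved the numbers only modestly: a 3.7-fold lower number from compound 1 to compound 2 (0.56 log units; beyond the scatter), a 2.8-fold lower number from compound 1 to compound 3 (0.44 log units; beyond the scatter) and a 1.3-fold higher number from compound 2 to compound 3 (0.12 log units; within the scatter). A step of similar or smaller size is therefore expected here, with no clear direction. Compound 4 is expected to give 30 nM in this assay, with a range from 10 nM to 90 nM, which as an estimate would mean a 1.3-fold lower number from compound 3 to compound 4 (0.12 log units; within the scatter).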

Compound 4, half-maximal inhibitory concentration: 110 nM
Compound 4: the middle estimate sits 3.7-fold (0.56 log units) below what was measured; measured number above the stated range.
By their numbers in this assay, from the lowest: compounds 2 and 3 (each within the scatter of the next); then compounds 1 and 4 (each within the scatter of the next).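

Replacing tert-butyl on this carbonyl carbon with 4-(dimethylamino)phenyl, which has more heavy atoms and adds a six-membered aromatic ring and a hydrogen-bond acceptor, gives a 2.8-fold higher number from compound 3 to compound 4 (0.44 log units; beyond the scatter) in this assay. Among the compounds shown here, this is the first measured step that alters the far end of the group on the amide carbonyl, and it shows that the number responds to what sits there: although modest, the step lies beyond the usual scatter, and tert-butyl is the better of the two groups compared. The data offer no measured explanation for why the number rises with this change.

The change brings in an aromatic ring and a dimethylamino group at once, so these two compounds cannot show which part accounts for the step; a plain phenyl in the same place would separate the ring from the amine. A cyclohexyl would go further, showing whether a ring of similar size without aromatic character behaves more like tert-butyl or more like 4-(dimethylamino)phenyl.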